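A few compounds are considered here, and "the series" means these few. Any claim that something is new, unique, unknown or untested is made for them only; others in the source may bear on it.

Three compounds sharing one core differ only in the group on a single aromatic carbon, ortho to an ethoxycarbonyl group. In a functional assay on Jurkat cells (Homo sapiens) for inhibition (a lower number here means a stronger inhibitor, a higher number a weaker inhibitor), compound 1 (`CCOC(=O)c1cnc(NN2C(=O)C=C(C)C2=O)nc1C(F)(F)F`), with trifluoromethyl, gives 2000 nM, and compound 2 (`CCOC(=O)c1cnc(NN2C(=O)C=C(C)C2=O)nc1C`), with methyl, gives 1900 nM. Compound 3 (`CCOC(=O)c1cnc(NN2C(=O)C=C(C)C2=O)nc1COC`), with methoxymethyl, gives 6000 nM, the highest number of the three and so the weakest inhibitor among them.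

Compound 4 (`CCOC(=O)c1cnc(NN2C(=O)C=C(C)C2=O)nc1-c1nccs1`) has 1,3-thiazol-2-yl in place of methoxymethyl at that carbon: 1,3-thiazol-2-yl in place of methoxymethyl on an aromatic carbon. Within the data shown here, no measured compound carries a ring there, so the evidence is indirect. The exchange of trifluoromethyl for methyl is a 1.1-fold lower number from compound 1 to compound 2 (0.02 log units; within the scatter). Going to methoxymethyl is a 3.0-fold higher number from compound 1 to compound 3 (0.48 log units; beyond the scatter), and likewise a 3.2-fold higher number from compound 2 to compound 3 (0.50 log units; beyond the scatter). Among these three compounds, then, methoxymethyl alone stands apart, and the two other groups give values within the scatter of each other. Removing it may bring compound 4 back towards compound 2 at 1900 nM, although the new ring leaves this uncertain. The expected change in this assay is a modest one towards a lower number, a 2.1-fold lower number from compound 3 to compound 4 (0.33 log units; beyond the scatter). For compound 4 the estimated value is 2800 nM, with an expected range of 900 nM to 8000 nM.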

Compound 4, half-maximal inhibitory concentration: 2200 nM
Compound 4: middle estimate off by 1.3-fold (0.10 log units), on the high side; measured number inside the range.
By their numbers in this assay, from the lowest: compounds 2, 1 and 4 (each within the scatter of the next); then compound 3.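

In this assay, putting 1,3-thiazol-2-yl in place of methoxymethyl gives a 2.7-fold lower number from compound 3 to compound 4 (0.44 log units; beyond the scatter), so a ring at this aromatic carbon does not carry the loss seen with methoxymethyl, even though the ring brings 5 heavy atoms where methoxymethyl has 3. The ring also falls within the scatter of both earlier groups, with a 1.2-fold higher number from compound 2 to compound 4 (0.06 log units; within the scatter) and a 1.1-fold higher number from compound 1 to compound 4 (0.04 log units; within the scatter), so methyl, trifluoromethyl and 1,3-thiazol-2-yl cannot be told apart at this carbon, and among the four compounds only compound 3 stands apart. No evidence is available that would explain why methoxymethyl alone differs from the other three groups.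

The compounds shown leave open whether this holds for rings in general, as a phenyl or a morpholine ring at this carbon could test, and how an amine or a carboxylic acid would behave there. They also leave open whether the ether oxygen of methoxymethyl or the length of its chain goes with the higher number, a question that an ethyl or a hydroxymethyl group at the same carbon would address.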